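Sulfone series: exchanging the bromo-hydroxyphenyl arm

The source may report more compounds than this note shows. Statements on the series, on what has been measured and on what is new or still open speak of the compounds shown alone.

The series is followed in a functional assay on DU-145 cells (Homo sapiens) for inhibition, read by trypan blue exclusion, with a stated time of 96 h; a lower number here means a stronger inhibitor of growth, a higher number a weaker inhibitor of growth. Compound 1, `Cc1ccc(S/C(=C/c2c[nH]c3ccccc23)C(=O)c2ccc(Br)cc2)cc1`, gives 10000 nM in this assay. Compound 2, `O=C(/C(=C\c1ccc(Br)c(O)c1)S(=O)(=O)c1ccc(Br)cc1)c1ccc(Br)cc1`, gives 50000 nM. Among the measured compounds shown here, compound 2 therefore stands with the highest of the two numbers so far; the nearest is compound 1, whose number is lower by a gap beyond the usual scatter. For the measured compounds named here, no pair of measured compounds differs in only one place, so compound 1 and compound 2 are read through their two values alone.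

Compound 3, `O=C(/C(=C\c1ccc(F)cc1)S(=O)(=O)c1ccc(Br)cc1)c1ccc(Br)cc1`, is not yet measured. It differs from compound 2 in one place: 4-fluorophenyl in place of 4-bromo-3-hydroxyphenyl on a double-bonded chain carbon bound to a double-bonded chain carbon. Going by the values given here, no measured pair reports the effect of this exchange on its own. The expected step is a 1.7-fold lower number from compound 2 to compound 3 (0.22 log units; within the scatter), small and possibly within the usual scatter, leaning toward a lower number. Compound 3 is estimated at 30000 nM in this assay, with a range from 8000 nM to 100000 nM.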

Compound 3, concentration for 50% growth inhibition: 4000 nM
Beside the measured number, compound 3's estimate is 7.5-fold (0.88 log units) above it; the whole stated range lies above it.
By their numbers in this assay, from the lowest: compound 3; then compound 1; then compound 2.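

Among the compounds shown here, on the double-bonded chain carbon bound to a double-bonded chain carbon, the exchange of 4-bromo-3-hydroxyphenyl for 4-fluorophenyl in this assay gives a 13-fold lower number from compound 2 to compound 3 (1.10 log units; beyond the scatter) as the first single-place reading. The aryl arm at this place can therefore move the number strongly while the rest of compound 2 stays unchanged. Nothing available here accounts for the size of this step.

The exchange alters the bromo and hydroxy substituents and brings in fluoro at once, so the compounds shown do not separate the contribution of each. Going by these compounds, whether an unsubstituted phenyl or a 4-aminophenyl arm at this place would give a number closer to compound 2 or to compound 3 also stays open.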